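A few compounds are considered here, and "the series" means these few. Any claim that something is new, unique, unknown or untested is made for them only; others in the source may bear on it.

Compound 1 `CCCCNc1nnc(SCC(=O)N(Cc2cccc([N+](=O)[O-])c2)c2ccc(F)cc2)s1` and compound 2 `C=CCNc1nnc(SCC(=O)N(Cc2cccc([N+](=O)[O-])c2)c2ccc(F)cc2)s1` share one core and differ only in the chain on a nitrogen on an aromatic ring. In an assay on isolated protein for inhibition of Amine oxidase [flavin-containing] A (Homo sapiens), read by fluorescence and Amplex Red, with a stated time of 30 min, tested at 10 uM (a lower number here means a weaker effect, a higher number a stronger effect of the compound at the concentration tested), compound 1 gives 76%, and compound 2 gives 75.2%; the step of a number 0.8 percentage points lower from compound 1 to compound 2 (within the scatter) is within the scatter, so compound 2 stands together with compound 1 rather than apart from it. Compound 3 `CC(C)Nc1nnc(SCC(=O)N(Cc2cccc([N+](=O)[O-])c2)c2ccc(F)cc2)s1` carries the change (isopropyl in place of allyl on a nitrogen on an aromatic ring). For the measured compounds named here, the only measured step that bears on it, between compound 1 and compound 2, stayed within the scatter, so in this assay no step beyond the scatter is expected. Compound 3 is therefore expected to give 73%, in the range 58% to 86%. The expected step is a number 2.2 percentage points lower from compound 2 to compound 3 (within the scatter).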

Compound 3, a percentage reported as inhibition, at one concentration (the size of the read-out at that concentration, not a potency): 86.1%
Beside the measured number, compound 3's estimate is 13.1 percentage points below it, and the stated range ends below it.
By their numbers in this assay, from the lowest: compounds 2 and 1 (each within the scatter of the next); then compound 3.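

In this assay, the chain on a nitrogen on an aromatic ring now makes a difference: isopropyl in place of allyl, with the same count of heavy atoms, gives a number 10.9 percentage points higher from compound 2 to compound 3 (beyond the scatter), and isopropyl in place of butyl gives a number 10.1 percentage points higher from compound 1 to compound 3 (beyond the scatter). For the compounds shown here, the two unbranched chains had stood within the scatter of each other, so compound 3, with its branched chain, is the first to stand apart. Nothing available here accounts for this step.

Going by these compounds, whether a bulkier branched group such as tert-butyl, or a ring such as cyclopropyl, would keep or extend this step remains open. So does whether a hydroxyl group on the chain would do the same.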